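Amide aryl variation on the shared core: toward compound 4

A few compounds are considered here, and "the series" means these few. Any claim that something is new, unique, unknown or untested is made for them only; others in the source may bear on it.

Within the data shown here, the three measured members share one core and differ only in the aryl group on the amide carbonyl. Compound 1 `O=C(Nc1cccc(-c2oc3cc(-c4ccc(F)cc4)ccc3c(=O)c2O)c1)c1ccc(F)cc1` gives 16000 nM in a functional assay on MDA-MB-231 cells (Homo sapiens) for antiproliferative activity, read by CCK-8 assay, with a stated time of 72 h; a higher number here means a weaker inhibitor, a lower number a stronger inhibitor. Compound 2 `O=C(Nc1cccc(-c2oc3cc(-c4ccc(F)cc4)ccc3c(=O)c2O)c1)c1ccc(C(F)(F)F)cc1` gives 29400 nM in this assay. Compound 3 `O=C(Nc1cccc(-c2oc3cc(-c4ccc(F)cc4)ccc3c(=O)c2O)c1)c1cccc(F)c1` gives 2510 nM in this assay. Compound 2 carries the highest number of the three: its nearest neighbour is compound 1, with a 1.8-fold higher number from compound 1 to compound 2 (0.26 log units; within the scatter), and its furthest is compound 3, with a 12-fold lower number from compound 2 to compound 3 (1.07 log units; beyond the scatter); the other measured step is a 6.4-fold lower number from compound 1 to compound 3 (0.80 log units; beyond the scatter).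

Compound 4 `COc1cc(OC)cc(C(=O)Nc2cccc(-c3oc4cc(-c5ccc(F)cc5)ccc4c(=O)c3O)c2)c1` is not yet measured. Relative to compound 2 the change is 3,5-dimethoxyphenyl in place of 4-(trifluoromethyl)phenyl on a carbonyl carbon.

Among the measured compounds shown here, no measured step exchanges a 4-substituted aryl for a 3,5-disubstituted one. For the measured compounds named here, the only steps that bear on it are those leaving compound 2: the within-scatter move to compound 1 and the large drop to compound 3, where a substituent at the 3-position of the phenyl replaced a 4-substituent. On that basis a decrease in number is expected for compound 4, but of uncertain size, so a 3.7-fold lower number from compound 2 to compound 4 (0.57 log units; beyond the scatter) is estimated. Compound 4 is therefore expected to give about 8000 nM in this assay, within 2500 nM to 25000 nM.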

Compound 4, half-maximal inhibitory concentration: 4040 nM
The estimate for compound 4 lay 2.0-fold (0.30 log units) above the measured number, and the stated range covers the measured number.
By their numbers in this assay, from the lowest: compounds 3 and 4 (each within the scatter of the next); then compounds 1 and 2 (each within the scatter of the next).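

In this assay, placing 3,5-dimethoxyphenyl on the carbonyl carbon gives a 7.3-fold lower number from compound 2 to compound 4 (0.86 log units; beyond the scatter) and a 4.0-fold lower number from compound 1 to compound 4 (0.60 log units; beyond the scatter), so the lower number is no longer confined to the 3-fluorophenyl amide. Against that amide the change gives a 1.6-fold higher number from compound 3 to compound 4 (0.21 log units; within the scatter), which leaves the two aryl groups unordered; across these four compounds, both aryl groups lacking a 4-substituent stand beyond the scatter from both that carry one, and none goes against this. Nothing available explains the difference between these aryl groups.

The compounds shown cannot separate the loss of the 4-substituent from the presence of the 3,5-dimethoxy pattern. A phenyl bearing a single methoxy group, an unsubstituted phenyl, or a phenyl carrying an amine or a carboxylic acid would test how far this holds.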